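The source may hold more compounds than are shown below. What is called first, only, known or untested is meant among the compounds shown, and "the series" means these compounds.

Of the compounds shown here, three sharing one core have been tested in a functional assay on MDA-MB-231 cells (Homo sapiens) for antiproliferative activity, read by MTT assay, with a stated time of 24 h; on this read-out higher numbers stand for weaker inhibition and lower numbers for stronger inhibition. Compound 1 `CCCCc1oc2ccccc2c1C(=O)c1ccc(OCC(=O)N2CCCC2)cc1` gives > 50000 nM, which is a limit of the assay and not a number. Compound 2 `CCCCNC(=O)CCCOc1ccc(C(=O)c2c(CCCC)oc3ccccc23)cc1` gives 38100 nM, and compound 3 `CCCCc1oc2ccccc2c1C(=O)c1ccc(OCCCC(=O)N2CCCC2)cc1` gives 48700 nM, so these two measured values lie within the usual scatter of each other.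

Compound 4 `CCCCc1oc2ccccc2c1C(=O)c1ccc(OCCCC(=O)N2CCCCC2)cc1` has piperidin-1-yl in place of pyrrolidin-1-yl on a carbonyl carbon. Among the compounds with values here, the closest precedent is a change at that same kind of carbon, butylamino to pyrrolidin-1-yl, which gave a 1.3-fold higher number from compound 2 to compound 3 (0.11 log units; within the scatter). The two steps that alter the chain, an at least 1.3-fold lower number from compound 1 to compound 2 (0.11 log units; that floor lies within the scatter) and an at least 1.0-fold lower number from compound 1 to compound 3 (0.01 log units; that floor lies within the scatter), start from the limit and show no clear change either. None of the steps seen so far in this assay goes beyond the scatter, so none is expected here, and the expected change is a 1.2-fold lower number from compound 3 to compound 4 (0.09 log units; within the scatter). For compound 4 the estimated value is 40000 nM, with an expected range from 18000 nM to 65000 nM.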

Compound 4, half-maximal inhibitory concentration: 36000 nM
Compound 4: the middle estimate sits 1.1-fold (0.05 log units) above what was measured; the range from low to high includes it.
By their numbers in this assay, from the lowest: compounds 4, 2 and 3 (each within the scatter of the next). At a limit, above all of these: compound 1.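

In this assay, piperidin-1-yl in place of pyrrolidin-1-yl on the carbonyl carbon gives a 1.4-fold lower number from compound 3 to compound 4 (0.13 log units; within the scatter) and butylamino replaced by piperidin-1-yl gives a 1.1-fold lower number from compound 2 to compound 4 (0.02 log units; within the scatter) so a six-membered ring now joins the five-membered ring and the open butylamino group with no change beyond the scatter. Compound 1 stands at a limit and not a number: (the limit of > 50000 nM in this assay, at which 1 of the 4 values shown sits). Its step therefore sets only a floor on any difference made by the longer chain together with the new ring (an at least 1.3-fold lower number from compound 1 to compound 4 (0.14 log units; that floor lies within the scatter)).

Going by these compounds, what remains open is whether any group on this carbonyl carbon can move the number beyond the scatter, such as morpholin-4-yl or piperazin-1-yl, or a carboxylic acid in place of the amide. A chain longer than the one in compound 4 also remains untested in what is shown here.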